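The compounds below may be only part of what the source reports. "The series", "measured", "known", "first", "only" and "open" are said of these compounds alone.

Three compounds of a shared core, in which a central carbon bearing a double bond to nitrogen links two amide-type nitrogens, have been tested in an ADME assay on MCF-10A cells (Homo sapiens) for cytotoxicity, read by MTT assay, with a stated time of 72 h; a lower number here means a stronger inhibitor of growth, a higher number a weaker inhibitor of growth. Compound 1 `CS/C(=N\C(=O)c1ccno1)NC(=O)c1ccno1` gives 16900 nM in this assay, the highest of the three numbers, which means it is the weakest inhibitor of growth among them. Compound 2 `C[Se]/C(=N\C(=O)c1ccco1)NC(=O)c1ccco1` gives 5940 nM in this assay, a step lower that lies beyond the usual scatter. Compound 3 `CS/C(=N\C(=O)c1cc2ccccc2s1)NC(=O)c1cc2ccccc2s1` gives 20 nM in this assay, far below the other two.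

Compound 4 `O=C(/N=C(/NC(=O)c1ccno1)[Se]Cc1ccccc1)c1ccno1` has not yet been measured. It differs from compound 1 in one place: a group of 8 heavy atoms (7 carbon, 1 selenium; one six-membered aromatic ring of carbon only) in place of a group of 2 heavy atoms (1 carbon, 1 sulfur; no ring), on a carbon with a double bond to nitrogen. The two ends of the core, the amides on the five-membered aromatic rings, are kept unchanged.

No direct comparison for such a change exists among the measured compounds. Compound 2 carries selenium and shows a lower number than compound 1, but it also differs at both amide ends, so no single cause can be read from that pair. A modest step downward is expected from compound 1 to compound 4, estimated at a 2.8-fold lower number from compound 1 to compound 4 (0.45 log units; beyond the scatter). For compound 4 the estimated value in this assay is 6000 nM, with a likely range from 1500 nM to 20000 nM.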

Compound 4, concentration for 50% growth inhibition: 7800 nM
Compound 4: the middle estimate sits 1.3-fold (0.11 log units) below what was measured; measured number inside the range.
By their numbers in this assay, from the lowest: compound 3; then compounds 2 and 4 (each within the scatter of the next); then compound 1.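

For the compounds shown here, with the amide ends of compound 1 kept unchanged, this is the first direct look at the group on the carbon with a double bond to nitrogen. In this assay, replacing methylsulfanyl with the group of selenium and seven carbons, which includes a six-membered aromatic ring, gives a 2.2-fold lower number from compound 1 to compound 4 (0.34 log units; beyond the scatter), a modest step that lies beyond the scatter, so this place accepts a much larger group here without a rise in the number. No measurement is available that explains the step.

This single step combines two changes, the exchange of sulfur for selenium and the growth of the group to include an aromatic ring, so the compounds shown leave open how much of the step belongs to each. Also open, on these data alone, is how the number would respond to a different group in this place, such as a straight butyl chain on the selenium or an amine on the carbon, and whether the same step would appear with other amide ends.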